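The source may hold more compounds than are shown below. What is called first, only, known or untested is meant among the compounds shown, and "the series" means these compounds.

Of the compounds shown here, three sharing one core have so far been tested in a functional assay on MCF7 cells (Homo sapiens) for inhibition, read by MTT assay, with a stated time of 72 h; a higher number here means a weaker inhibitor, a lower number a stronger inhibitor. Compound 1 `CC(C)n1ncc2c(C(=O)NCc3ccccc3)cccc21` is the simplest of them; in this assay compound 1 gives only a limit, > 40000 nM. Compound 2 `CC(C)n1ncc2c(C(=O)NCc3cn(-c4ccc(I)cc4)nn3)cccc21` carries a 4-iodophenyl group on a five-membered aromatic ring with three nitrogens; compound 2 likewise reaches only a limit, > 40000 nM. Compound 3 `CC(C)n1ncc2c(C(=O)NCc3cn(-c4cccc(Br)c4)nn3)cccc21` carries a 3-bromophenyl group at that same place; compound 3 again stops at a limit, > 40000 nM. The step between the two halogen-bearing rings, a step that the two limits leave unreadable from compound 2 to compound 3, cannot be sized, because of the limit of > 40000 nM in this assay, at which 3 of the 3 values shown sit. Compound 3 therefore stands nowhere distinct among the three: all that is known is that it is a weak inhibitor, if it inhibits at all.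

Compound 4 `Cc1ccccc1-n1cc(CNC(=O)c2cccc3c2cnn3C(C)C)nn1` differs from compound 3 in one place: 2-methylphenyl in place of 3-bromophenyl on an aromatic nitrogen. Among the compounds with values here, no measured step bears on this change, as the only single-point step recorded is unreadable and every value so far is a limit. There is thus no basis to expect compound 4 to move beyond the scatter. The step from compound 3 to compound 4 is estimated at a step that the limit leaves unreadable from compound 3 to compound 4. Compound 4 is accordingly expected at 60000 nM, within a range from 20000 nM to 200000 nM, and will most probably be reported as a limit once more.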

Compound 4, half-maximal inhibitory concentration: > 40000 nM
Compound 4 ended at the assay's limit (the forecaster's own chance of this, stated with the estimate: 85%); the middle value is on the limit's open side.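

Compound 4 also stops at a limit, so the steps to compound 4 from compound 2 and compound 3 cannot be read, because all the values share one ceiling: (the limit of > 40000 nM in this assay, at which 4 of the 4 values shown sit). In this assay the compounds shown leave open whether any group on the aromatic nitrogen can give a measurable value rather than a limit.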